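A few compounds are considered here, and "the series" means these few. Any claim that something is new, unique, unknown or untested is made for them only; others in the source may bear on it.

Measured compounds in an assay on CHO cells for displacement of a labelled ligand from adenosine receptor A1 (Homo sapiens), read by scintillation counting, with a stated time of 90 min, in the presence of a further agent that is not named here; a higher number here means a weaker inhibitor, a lower number a stronger inhibitor:
- compound 1, `CCCn1c(=O)[nH]c2nc(-c3ccc(S(=O)(=O)N4CCN(Cc5cccc(C)c5)CC4)cc3)[nH]c2c1=O`, gives 795 nM
- compound 2, `CCCn1c(=O)[nH]c2nc(-c3ccc(S(=O)(=O)N4CCN(Cc5cccc(Br)c5)CC4)cc3)[nH]c2c1=O`, gives 928 nM
- compound 3, `CCCn1c(=O)[nH]c2nc(-c3ccc(S(=O)(=O)N4CCN(c5ccccc5Br)CC4)cc3)[nH]c2c1=O`, gives > 1000 nM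

All three share one core and differ only in the group carried on the ring nitrogen of the six-membered ring with two nitrogens. Compound 1 carries a 3-methylbenzyl group there, compound 2 a 3-bromobenzyl group, and compound 3 a 2-bromophenyl group. For compound 3 only a limit of this assay is known, not a number (the limit of > 1000 nM in this assay, at which 1 of the 3 values shown sits). Compound 3 therefore stands at the weak end of what has been measured, though its floor sits within the scatter of the other two values, as an at least 1.2-fold higher number from compound 1 to compound 3 (0.09 log units; that floor lies within the scatter) and an at least 1.0-fold higher number from compound 2 to compound 3 (0.03 log units; that floor lies within the scatter) show.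

Compound 4, `CCCn1c(=O)[nH]c2nc(-c3ccc(S(=O)(=O)N4CCN(c5ccc(C)cc5)CC4)cc3)[nH]c2c1=O`, is the next member: 4-methylphenyl in place of 2-bromophenyl on an amine nitrogen in a ring. The swap of bromo for methyl on an aromatic carbon was already seen once, in a 1.2-fold higher number from compound 1 to compound 2 (0.07 log units; within the scatter), and made no difference beyond the scatter. Compound 4 keeps the directly attached phenyl of compound 3 rather than the benzyl of compounds 1 and 2, so the step that the limit leaves unreadable from compound 3 to compound 4 is expected to be small and to stay near the limit. Compound 4 is thus expected to give about 1500 nM in this assay, in a range from 600 nM to 5000 nM, and may again be reported only as a limit.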

Compound 4, inhibition constant: > 1000 nM
Compound 4: no number, only a limit (the forecaster's own chance of this, stated with the estimate: 55%); the middle value lies beyond the limit too.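

In this assay compound 4 gives a limit and not a number, and a second directly attached phenyl group, here 4-methylphenyl in place of 2-bromophenyl, now stands at the same limit as compound 3: the limit of > 1000 nM in this assay, at which 2 of the 4 values shown sit. The step from compound 3 to compound 4 cannot be read, so this pair shows no measurable effect of the swap, and no real difference between the two groups can be claimed either. Against the benzyl compounds the result gives only floors, an at least 1.2-fold higher number from compound 1 to compound 4 (0.09 log units; that floor lies within the scatter) and an at least 1.0-fold higher number from compound 2 to compound 4 (0.03 log units; that floor lies within the scatter), so neither comparison shows that a directly attached phenyl differs from a benzyl on this amine nitrogen in a ring.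

Going by these compounds, how far compound 3 and compound 4 lie past their limits stays open, and with it whether either of them truly differs from compound 1 or compound 2 in this assay. Also open, on these data alone, is what a quite different group on this nitrogen would give, such as an acetyl group, a plain alkyl chain or a phenyl ring carrying a carboxylic acid.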